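A few compounds are considered here, and "the series" means these few. Any claim that something is new, unique, unknown or untested is made for them only; others in the source may bear on it.

Measured compounds in an assay on isolated protein for displacement of a labelled ligand from 5-hydroxytryptamine receptor 7 (Homo sapiens); a lower number here means a stronger inhibitor, a higher number a weaker inhibitor:

Compound 1 `Cc1[nH]c2ccccc2c1C1=CCNCC1`: compound 1 gives > 1000 nM, a limit of this assay.
Compound 2 `Cc1[nH]c2ccc(OS(=O)(=O)C(F)(F)F)cc2c1C1=CCNCC1`: compound 2 gives 1800 nM.
Compound 3 `Cc1[nH]c2ccc([N+](=O)[O-])cc2c1C1=CCNCC1`: compound 3 gives > 1000 nM, a limit of this assay.

Compound 3 therefore stands only at a limit in this assay, where (the limit of > 1000 nM in this assay, at which 2 of the 3 values shown sit); no number is known for it.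

Compound 4 `Cc1[nH]c2ccc(-c3ccsc3)cc2c1C1=CCNCC1` differs from compound 3 by one change: thiophen-3-yl in place of nitro on an aromatic carbon.

The measured steps that reach compound 3 are a step that the two limits leave unreadable from compound 1 to compound 3 and a step that the limit leaves unreadable from compound 2 to compound 3. Neither gives a size, and the step from compound 1 to compound 2, a step that the limit leaves unreadable from compound 1 to compound 2, is unreadable as well. No direction for the change to a thiophen-3-yl group can be read from them.

The step from compound 3 to compound 4 is therefore expected only loosely, as an at least 1.2-fold lower number from compound 3 to compound 4 (0.09 log units; that floor lies within the scatter). Compound 4 is estimated at 800 nM, within 150 nM to 4000 nM.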

Compound 4, half-maximal inhibitory concentration: 690 nM
Beside the measured number, compound 4's estimate is 1.2-fold (0.06 log units) above it, within the range that was stated.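

In this assay, this position now shows a step of readable size beyond the scatter, with thiophen-3-yl in place of ((trifluoromethyl)sulfonyl)oxy: a 2.6-fold lower number from compound 2 to compound 4 (0.42 log units; beyond the scatter). Against nitro and hydrogen, only floors within the scatter can be read, an at least 1.4-fold lower number from compound 3 to compound 4 (0.16 log units; that floor lies within the scatter) and an at least 1.4-fold lower number from compound 1 to compound 4 (0.16 log units; that floor lies within the scatter), so neither change has a fixed size. The steps among compound 1, compound 2 and compound 3 cannot be read, because of the assay limit: the limit of > 1000 nM in this assay, at which 2 of the 4 values shown sit.

As far as these compounds go, it remains open how far compound 1 and compound 3 truly lie from compound 4. Also open, from the compounds shown here alone, is whether a phenyl ring or an amine on this aromatic carbon would fall near thiophen-3-yl.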